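The compounds below may be only part of what the source reports. "The series", "measured", "known", "first", "only" and "open" are said of these compounds alone.

Compounds measured:
compound 1, `COc1cc(-c2cc(/C=C/C(=O)c3ccc(N)cc3)[nH]n2)cc(OC)c1OC`, -12% in a functional assay on HCT-15 cells (Homo sapiens) for cytotoxicity, read by sulforhodamine B assay, with a stated time of 48 h, tested at 10 uM; a higher number here means a weaker effect of the compound at the concentration tested, a lower number a stronger effect
compound 2, `COc1cc(-c2cc(/C=C/C(=O)c3ccc(Cl)c(Cl)c3)[nH]n2)cc(OC)c1OC`, 29%

Among these two numbers compound 2 stands highest in this assay; its nearest neighbour is compound 1, and the step of a number 41 percentage points higher from compound 1 to compound 2 (beyond the scatter) lies beyond the scatter. Going by the values given here, that step exchanges the group on the carbonyl carbon, 3,4-dichlorophenyl in place of 4-aminophenyl, so the aryl on the carbonyl carbon is the only place where a change has so far been followed.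

Compound 3, `COc1ccc(C(=O)/C=C/c2cc(-c3cc(OC)c(OC)c(OC)c3)n[nH]2)cc1OC`, has not yet been measured in this assay. It differs from compound 2 at that same place: 3,4-dimethoxyphenyl in place of 3,4-dichlorophenyl on a carbonyl carbon. Among the compounds with values here, the one measured step that bears on it is a number 41 percentage points higher from compound 1 to compound 2 (beyond the scatter), which was large, so a change at this position can move the read-out well beyond the scatter. That step, however, ran from an aminophenyl to a dichlorophenyl, and nothing measured tells which way a dimethoxyphenyl falls between them. Compound 3 is therefore expected to lie roughly between the two measured values, with a step of a number 17 percentage points lower from compound 2 to compound 3 (beyond the scatter), and its estimate in this assay is 12%, in the range -15% to 45%.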

Compound 3, a percentage reported as activity, at one concentration (the size of the read-out at that concentration, not a potency): -78%
Beside the measured number, compound 3's estimate is 90 percentage points above it; the whole stated range lies above it.
By their numbers in this assay, from the lowest: compound 3; then compound 1; then compound 2.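

At the aryl on the carbonyl carbon, the read-out in this assay is not confined to the span set by the aminophenyl and the dichlorophenyl, as the 3,4-dimethoxyphenyl group takes it past both: the change gives a number 107 percentage points lower from compound 2 to compound 3 (beyond the scatter) and, against the other measured aryl, a number 66 percentage points lower from compound 1 to compound 3 (beyond the scatter). Going by these compounds alone, this position therefore has a much wider reach than the single earlier step showed, and compound 3 has the lowest number of the three, with each of its steps beyond the scatter; the exchange for 3,4-dichlorophenyl brings in two oxygen atoms and 2 hydrogen-bond acceptors in place of two chlorine atoms and none, but this count alone does not identify what drives the difference. No evidence at hand accounts for the size or direction of these steps.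

The compounds shown leave open whether both methoxy groups are needed, since a single methoxy group or a 3,4-dihydroxyphenyl group at the same carbonyl carbon would separate their contributions. They also leave open whether the 3,4-dimethoxyphenyl group would keep its standing if the 3,4,5-trimethoxyphenyl group on the shared core gave way to an unsubstituted phenyl.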